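The compounds below may be only part of what the source reports. "The series", "measured", "known", "first", "only" and "open" are said of these compounds alone.

The measured compounds, each in a physicochemical assay for acid dissociation:

Compound 1, `COc1cccc(CNCCCNc2ccnc3cc(C4CCCCC4)ccc23)c1O`, gives 9.47.
Compound 2, `COc1ccc(F)cc1CNCCCNc1ccnc2cc(C3CCCCC3)ccc12`, gives 9.47.
Compound 3, `COc1cccc(CNCCCNc2ccnc3cc(Cc4ccc(C#N)cc4)ccc23)c1O`, gives 9.47.

Compound 2 stands level with compounds 1 and 3 at the digits shown; its nearest neighbour is compound 1 and its furthest is compound 3, and neither gap lies beyond the scatter. The two recorded steps say the same: no change at the digits printed from compound 1 to compound 2 (within the scatter), and no change at the digits printed from compound 1 to compound 3 (within the scatter). The second of these is the one that bears on the step now at hand, since it also changes the group on the aromatic carbon of the shared core, and it left the read-out unmoved.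

Compound 4, `COc1ccc(F)cc1CNCCCNc1ccnc2cc(CC3CCCCC3)ccc12`, has not yet been measured. It differs from compound 2 in one place: cyclohexylmethyl in place of cyclohexyl on an aromatic carbon. Among the measured compounds shown here, the group that leaves and the group that enters are both saturated carbon rings of the same size, and the only measured change at that aromatic carbon, swapping cyclohexyl for a much larger 4-cyanobenzyl, produced no shift beyond the scatter. The expectation is therefore a step of no change at the digits printed from compound 2 to compound 4 (within the scatter), meaning none beyond the scatter. Compound 4 is estimated to give 9.47 in this assay, expected to fall between 9.2 and 9.75.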

Compound 4, acid dissociation constant: 9.47
Beside the measured number, compound 4's estimate shows no gap at the digits printed; low and high end bracket the measured number.
By their numbers in this assay, from the lowest: compounds 1, 2, 3 and 4 (each within the scatter of the next).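

In this assay, the step of no change at the digits printed from compound 2 to compound 4 (within the scatter) carries the picture of this aromatic carbon over to a second setting: the earlier change there, no change at the digits printed from compound 1 to compound 3 (within the scatter), was read with the 2-hydroxy-3-methoxyphenyl group in the molecule, whereas this one is read with the 5-fluoro-2-methoxyphenyl group. It also adds cyclohexylmethyl, a group of saturated carbon alone, to the nitrile-bearing 4-cyanobenzyl, so two quite different groups have now each replaced cyclohexyl at this place without a shift beyond the scatter. What lies behind this flat read-out cannot be said from these compounds, as no supporting data bear on it.

Still open, from the compounds shown here alone, is whether an amine or a carboxylic acid on this aromatic carbon would leave the read-out just as flat, since every group seen there so far is built on a carbon ring with no such function. Equally open, going by these compounds, is what a longer chain would do, either in place of cyclohexylmethyl at this carbon or in place of the saturated chain that carries the amine nitrogen.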